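The source may report more compounds than this note shows. Statements on the series, on what has been measured and on what is new or still open speak of the compounds shown alone.

Measured so far:
compound 1 `CCCCC(Sc1ccc(OCCCOc2cccc(C)c2)cc1)C(=O)O`: 4800 nM
compound 2 `CCCCC(Sc1ccc(OCCCOc2ccccc2OC)cc1)C(=O)O`: > 10000 nM
compound 3 `CCCCC(Sc1ccc(OCCCOc2cccc3c2CCCC3)cc1)C(=O)OCC`: > 10000 nM

In an assay on isolated protein for inhibition of Polyunsaturated fatty acid 5-lipoxygenase (Homo sapiens), read by HPLC, with a stated time of 15 min, in the presence of a further agent that is not named here (a higher number here means a weaker inhibitor, a lower number a stronger inhibitor), compound 1 gives 4800 nM. Compound 2 gives > 10000 nM, which is a limit of this assay and not a number. Compound 3 likewise gives > 10000 nM, again a limit. Among the measured compounds shown here, compound 2 therefore stands at the limit of > 10000 nM in this assay, at which 2 of the 3 values shown sit, and the only measured single step, an at least 2.0-fold higher number from compound 1 to compound 2 (0.31 log units; beyond the scatter), ends there.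

Compound 4 `CCCCC(Sc1ccc(OCCCOc2ccc(Cl)cc2OC)cc1)C(=O)O` differs from compound 2 by chloro in place of hydrogen on an aromatic carbon. No measured step covers this kind of change, so the one step shown gives no direction for it. With compound 2 already at the limit, compound 4 is expected to stay close to that limit, with the estimated step of an at least 1.1-fold lower number from compound 2 to compound 4 (0.04 log units; that floor lies within the scatter) small. The estimate for compound 4 in this assay is 9000 nM, between 3000 nM and 25000 nM.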

Compound 4, half-maximal inhibitory concentration: > 10000 nM
Compound 4: only a limit was reported; the forecaster's own chance of this, stated with the estimate: 55%; middle value at least 1.1-fold (0.04 log units) away from the limit.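

In this assay compound 4 gives > 10000 nM, a limit and not a number, so chloro on this aromatic carbon, para to a large group, does not bring the 2-methoxyphenyl compound into the measurable range, and the step between the two limits cannot be read. Exchanging 3-methylphenyl for 4-chloro-2-methoxyphenyl gives an at least 2.0-fold higher number from compound 1 to compound 4 (0.31 log units; beyond the scatter). Most of the series now sits at one ceiling: the limit of > 10000 nM in this assay, at which 3 of the 4 values shown sit.

As far as these compounds go, whether chloro moves potency at all in this 2-methoxyphenyl series remains open. Also open, from the compounds shown here alone, is how an amine or a nitrile in place of chloro at this position would read.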